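The Same Halogen Swap Carried onto a Second Core

A few compounds are considered here, and "the series" means these few. Any claim that something is new, unique, unknown or untested is made for them only; others in the source may bear on it.

Three compounds have been measured in a functional assay on UACC-62 cells (Homo sapiens) (on this read-out lower numbers stand for stronger inhibition of growth and higher numbers for weaker inhibition of growth), with these outcomes:

compound 1 `O=S(=O)(/C=C/c1ccc(F)cc1)Cc1ccc(Nc2ncnc3ccccc23)cc1`: 5000 nM
compound 2 `O=S(=O)(/C=C/c1ccc(Br)cc1)Cc1ccc(Nc2ncnc3ccccc23)cc1`: > 100000 nM, a limit of the assay and not a number
compound 3 `COc1cc2ncnc(Nc3ccc(CS(=O)(=O)/C=C/c4ccc(F)cc4)cc3)c2cc1OC`: > 100000 nM, a limit of the assay and not a number

Compound 1 and compound 2 share one core and differ in a single place: bromo in place of fluoro on an aromatic carbon. In this assay this change brought an at least 20-fold higher number from compound 1 to compound 2 (1.30 log units; beyond the scatter). The result for compound 2 sits at the limit of > 100000 nM in this assay, at which 2 of the 3 values shown sit, so the true size of that step is not known, only that it is at least as large as stated.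

Compound 3 carries a different core; the difference between the two cores is not broken down here. Compound 4 `COc1cc2ncnc(Nc3ccc(CS(=O)(=O)/C=C/c4ccc(Br)cc4)cc3)c2cc1OC` has not yet been measured in this assay. Among the measured compounds shown here, it differs from compound 3 by bromo in place of fluoro on an aromatic carbon, the same change as the one made from compound 1 to compound 2, at the same kind of place on the ring.

Compound 3 already rests at the limit of this assay, and the earlier swap on the first core moved compound 2 in the direction of weaker growth inhibition, as an at least 20-fold higher number from compound 1 to compound 2 (1.30 log units; beyond the scatter) shows. On that basis compound 4 is expected to stay at or beyond the limit, the expected step being a step that the limit leaves unreadable from compound 3 to compound 4. Compound 4 is estimated at 250000 nM, with a likely range from 100000 nM to 1000000 nM.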

Compound 4, concentration for 50% growth inhibition: 63000 nM
For compound 4 the middle estimate is 4.0-fold (0.60 log units) above the measured one; the whole stated range lies above it.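

On the second core, bromo in place of fluoro gave an at least 1.5-fold lower number from compound 3 to compound 4 (0.20 log units; that floor lies within the scatter) in this assay, so the large rise in the number seen on the first core did not carry over to this one: the same change on two cores in this assay, an at least 20-fold higher number (1.30 log units; beyond the scatter) from compound 1 to compound 2 and an at least 1.5-fold lower number (0.20 log units; that floor lies within the scatter) from compound 3 to compound 4, at least 31-fold (1.50 log units) apart, beyond the scatter of two such steps

For compound 3 the result of > 100000 nM is a limit of the assay and not a number.

The pair therefore shows that this change cannot be assumed to act alike on these two cores, but it does not give the true size of either step, nor does it show how the core sets the outcome, and with only one pair on each core it supports no general rule for the series: the limit of > 100000 nM in this assay, at which 2 of the 4 values shown sit.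

The compounds shown leave open whether a halogen of intermediate size, chloro, would follow bromo or fluoro on either core, and whether a group of another kind on the phenyl ring, such as an amine or a carboxylic acid, would behave differently from both. They also leave open whether the difference between the two steps would hold with a single methoxy group on the core in place of the two carried by compound 3 and compound 4.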